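Aryl tail change: from compound 3 to compound 4

The source may report more compounds than this note shows. Statements on the series, on what has been measured and on what is new or still open speak of the compounds shown alone.

Measured values in a functional assay on PANC-1 cells (Homo sapiens) for inhibition, read by MTT assay, with a stated time of 72 h; a lower number here means a stronger inhibitor of growth, a higher number a weaker inhibitor of growth:
- compound 1 `O=S(=O)(NCCCCNCc1ccc(Br)cc1)c1cc(C(F)(F)F)cc(C(F)(F)F)c1` gives 2200 nM
- compound 2 `O=S(=O)(NCCCNCc1ccc(Cl)c(Cl)c1)c1cc(C(F)(F)F)cc(C(F)(F)F)c1` gives 5600 nM
- compound 3 `COc1ccc(CNCCCNS(=O)(=O)c2cc(C(F)(F)F)cc(C(F)(F)F)c2)cc1OC` gives 18000 nM

Compound 3 carries the highest number of the three. The two measured steps both lead upward to it: a 2.5-fold higher number from compound 1 to compound 2 (0.41 log units; beyond the scatter) and then a 3.2-fold higher number from compound 2 to compound 3 (0.51 log units; beyond the scatter), each beyond the scatter but modest. Within the data shown here, compound 1 and compound 3 have no single-point step between them; their two values simply show compound 3 with the clearly higher number.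

Compound 4 `O=S(=O)(NCCCNCC1COc2ccccc2O1)c1cc(C(F)(F)F)cc(C(F)(F)F)c1` differs from compound 3 by 2,3-dihydro-1,4-benzodioxin-2-yl in place of 3,4-dimethoxyphenyl on a saturated chain carbon bound to an amine nitrogen. Neither measured step speaks to this change directly. Both earlier steps altered the substituents on the aryl ring at the same chain position, whereas here the two methoxy groups are tied back into a second ring and the attachment point moves onto that non-aromatic ring. Among the measured compounds shown here, with nothing that tracks such a change, no step beyond the scatter is expected, although the earlier steps show that this position does move the number.

The step from compound 3 to compound 4 is estimated as a 1.1-fold lower number from compound 3 to compound 4 (0.05 log units; within the scatter). Compound 4 is therefore expected at about 16000 nM, within a range of 5000 nM to 45000 nM.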

Compound 4, concentration for 50% growth inhibition: 3400 nM
Estimate against measurement, compound 4: 4.7-fold (0.67 log units) above; the whole stated range lies above it.
By their numbers in this assay, from the lowest: compounds 1, 4 and 2 (each within the scatter of the next, the first and the last beyond it); then compound 3.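

In this assay, replacing the 3,4-dimethoxyphenyl on a saturated chain carbon bound to an amine nitrogen with 2,3-dihydro-1,4-benzodioxin-2-yl gives a 5.3-fold lower number from compound 3 to compound 4 (0.72 log units; beyond the scatter), even though the heavy atoms, hydrogen-bond donors and hydrogen-bond acceptors are unchanged in count; this position therefore responds to how the same atoms are arranged, and not only to which substituents a phenyl ring carries. Set against the 3,4-dichlorophenyl group, the same replacement gives a 1.6-fold lower number from compound 2 to compound 4 (0.22 log units; within the scatter), so no difference can be read between these two groups, and a phenyl ring bound directly to this chain carbon is not required for a number at the level of compound 2. Nothing measured here accounts for either step.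

Open, from the compounds shown here alone, is whether the two ring oxygens matter, which a 1,2,3,4-tetrahydronaphthalen-2-yl group, with carbon in place of both, would test at this place. Also open, going by these compounds, is whether a longer chain between the sulfonamide nitrogen and the amine nitrogen, of the kind in compound 1, would change the number when paired with the 2,3-dihydro-1,4-benzodioxin-2-yl group.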